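A few compounds are considered here, and "the series" means these few. Any claim that something is new, unique, unknown or untested is made for them only; others in the source may bear on it.

Compound 1 `CNc1nc(NCc2ccc(OC(F)(F)F)cc2)cc(-c2ccccn2)n1`: 13 nM
Compound 2 `c1ccc(-c2cc(NCC3CC3)ncn2)nc1`: 22000 nM
Compound 3 `COCCNc1nc(NCC2CC2)cc(-c2ccccn2)n1`: 2200 nM

Of the compounds shown here, three sharing one core have been measured in a functional assay on HEK293 cells for agonist activity at G-protein coupled receptor 39 (Homo sapiens), read by inositol phosphate accumulation; a lower number here means that less compound is needed, a higher number that more compound is needed for the effect. Compound 3 stands second highest of the three numbers. Its nearest neighbour is compound 2: the step from compound 2 to compound 3 was a 10-fold lower number from compound 2 to compound 3 (1.00 log units; beyond the scatter), a change that put (2-methoxyethyl)amino in place of hydrogen on an aromatic carbon. Among the compounds with values here, compound 1 lies far below compound 3 in this assay, but compound 1 differs from compound 3 in more than one place, so no single step connects them.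

Compound 4 `CC(C)(C)CNc1nc(NCC2CC2)cc(-c2ccccn2)n1` is not yet measured. It differs from compound 3 by tert-butyl in place of methoxymethyl on a saturated chain carbon bound to a nitrogen on an aromatic ring: the chain that leaves carries one hydrogen-bond acceptor, the one that enters carries none, and the alteration sits on a saturated chain carbon bound to a nitrogen on an aromatic ring. Within the data shown here, the only measured step, from compound 2 to compound 3, concerns the presence of this side chain rather than its make-up, so it bears on the change only loosely. Compound 4 is therefore expected to stay near compound 3, a step of a 1.5-fold lower number from compound 3 to compound 4 (0.17 log units; within the scatter) that is estimated to lie within or only slightly beyond the scatter. The estimate for compound 4 in this assay is 1500 nM, between 400 nM and 5000 nM.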

Compound 4, half-maximal effective concentration: 5000 nM
The estimate for compound 4 lay 3.3-fold (0.52 log units) below the measured number; measured number inside the range.
By their numbers in this assay, from the lowest: compound 1; then compound 3; then compound 4; then compound 2.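

In this assay the make-up of this side chain matters, not only its presence: tert-butyl, with no hydrogen-bond acceptor, in place of methoxymethyl, with one, gives a modest step beyond the scatter (a 2.3-fold higher number from compound 3 to compound 4 (0.36 log units; beyond the scatter)). An acceptor on the chain is not needed for a gain over hydrogen on the aromatic carbon, as neopentylamino still improves on hydrogen (a 4.4-fold lower number from compound 2 to compound 4 (0.64 log units; beyond the scatter)), though by less than (2-methoxyethyl)amino does (a 10-fold lower number from compound 2 to compound 3 (1.00 log units; beyond the scatter)). No measured evidence bears on what lies behind this difference.

The step from compound 3 to compound 4 changes the oxygen and the heavy-atom count together, so the compounds shown cannot tell which of the two matters, and a plain carbon chain such as n-propyl or n-butyl at this place would speak to that. Going by these compounds, it also remains open whether a 2-hydroxyethyl or 2-aminoethyl chain, or a longer 3-methoxypropyl chain, would carry the number lower than compound 3 or higher.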